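Methoxy in Place of Isopropyl on a Fused Ring

The source may report more compounds than this note shows. Statements on the series, on what has been measured and on what is new or still open speak of the compounds shown alone.

Of the compounds shown here, three built on a shared core have been tested in a functional assay on HCT-116 cells (Homo sapiens) for inhibition, read by CCK-8 assay, with a stated time of 72 h, tested at 20 uM; a higher number here means more inhibition of growth at the concentration tested, a lower number less inhibition of growth. Compound 1 `CCOC(=O)/C=C1/C(=O)Nc2ccccc21` gives 89.3%. Compound 2 `CN1C(=O)/C(=C/C(=O)OC(C)(C)C)c2ccccc21`, which carries a methyl on the amide nitrogen and a tert-butyl ester, gives 87.5%. Compound 3 `CC(C)c1ccc2c(c1)/C(=C\C(=O)OC(C)(C)C)C(=O)N2`, with an isopropyl on the fused aromatic ring and a tert-butyl ester, gives 89.4%. Compound 3 stands highest of the three numbers, yet its gap to compound 1, the nearest, and its gap to compound 2, the furthest, both lie within the scatter of this assay, so none of the three can be called more active than another.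

Compound 4 `COc1ccc2c(c1)/C(=C\C(=O)OC(C)(C)C)C(=O)N2` is the next compound to be measured. It differs from compound 3 in a single change: methoxy in place of isopropyl on an aromatic carbon. For the measured compounds named here, no pair of measured compounds shows this change, so its effect cannot be read from the data. Because compound 3 gives 89.4% and the three measured values all sit within the scatter of one another, the step of a number 3.4 percentage points lower from compound 3 to compound 4 (within the scatter) is expected to be small and of no direction beyond the scatter. Compound 4 is therefore estimated to reach about 86%, in a range from 72% to 95%.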

Compound 4, percent growth inhibition at one concentration: 89.6%
Compound 4: middle estimate off by 3.6 percentage points, on the low side, within the range that was stated.
By their numbers in this assay, from the lowest: compounds 2, 1, 3 and 4 (each within the scatter of the next).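

Methoxy in place of isopropyl on this aromatic carbon gives, in this assay, a number 0.2 percentage points higher from compound 3 to compound 4 (within the scatter). For the compounds shown here, this is the first pair of measured compounds that differ in one place, and it shows that at this position the exchange of a purely carbon group for one that brings a hydrogen-bond acceptor leaves the growth inhibition at the tested concentration unchanged within the scatter, so the reading does not separate the two groups. Nothing measured here bears on why the two groups read alike.

The compounds shown leave open whether the same position would tolerate an amine, a carboxylic acid or a longer chain such as butyl, or whether any group on this aromatic carbon would move the number beyond the scatter. They also leave open whether compound 3 and compound 4 would still read alike at lower concentrations, since a single tested concentration says nothing of how the inhibition of each falls away as the dose is reduced.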